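From phenylcarbamoyl to heptyl on compound 3

This account rests on a few compounds, and the source may have more. Where it says the series, first, only, none or still open, it means among the compounds named here.

Measured so far in a functional assay on A549 cells (Homo sapiens) for antiproliferative activity, read by sulforhodamine B assay, with a stated time of 48 h (a lower number here means a stronger inhibitor of growth, a higher number a weaker inhibitor of growth), for three compounds

Compound 1 `CCc1nc2nc(C(F)(F)F)ccc2c(=O)n1Cc1cn(CC(=O)Nc2ccccc2)nn1` gives 5260 nM
Compound 2 `CCc1nc2nc(C(F)(F)F)ccc2c(=O)n1Cc1cn(CCC(F)(F)C(F)(F)C(F)(F)C(F)(F)C(F)(F)C(F)(F)F)nn1` gives 30 nM
Compound 3 `O=C(Cn1cc(COc2nc(-c3ccccc3)nc3nc(C(F)(F)F)ccc23)nn1)Nc1ccccc1` gives 140 nM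

Compound 3 holds the middle place among these three numbers, with compound 2 lower and compound 1 higher, and both gaps lie beyond the usual scatter. Compound 4 `CCCCCCCCn1cc(COc2nc(-c3ccccc3)nc3nc(C(F)(F)F)ccc23)nn1` is still unmeasured. It places heptyl where compound 3 has phenylcarbamoyl, on a saturated chain carbon bound to an aromatic nitrogen: heptyl in place of phenylcarbamoyl on a saturated chain carbon bound to an aromatic nitrogen in full. Within the data shown here, no measured pair isolates this change. Among the measured compounds shown here, the only hint is compound 2, whose arm is also a chain without a ring and which gives 30 nM in this assay as the lowest number here. A modest drop is therefore expected, an estimated 2.0-fold lower number from compound 3 to compound 4 (0.30 log units; within the scatter) overall. For compound 4 the expected value is 70 nM with an estimated range from 15 nM to 350 nM in this uncertain case.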

Compound 4, concentration for 50% growth inhibition: 5330 nM
Beside the measured number, compound 4's estimate is 76-fold (1.88 log units) below it; the measured number lies above the stated range.
By their numbers in this assay, from the lowest: compound 2; then compound 3; then compounds 1 and 4 (each within the scatter of the next).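

In this assay, among these compounds, replacing phenylcarbamoyl with heptyl gives a 38-fold higher number from compound 3 to compound 4 (1.58 log units; beyond the scatter), the first comparison here in which only one place changes. It shows that growth inhibition depends strongly on the group at this saturated chain carbon bound to an aromatic nitrogen, and that with the rest of the molecule unchanged, phenylcarbamoyl gives much stronger inhibition than heptyl. Nothing available explains this difference.

On these data alone, the change removes the ring, carbonyl and amide hydrogen together, so which of them matters remains open. A benzyl group, which keeps a ring without the amide, or a methylcarbamoyl group, which keeps the amide without the ring, could help separate them.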